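This account rests on a few compounds, and the source may have more. Where it says the series, first, only, none or still open, it means among the compounds named here.

Compound 1, `O=C(O)CCc1ccc(OCc2nc(-c3ccccc3)no2)c(Cl)c1`, is tested in a functional assay on CHO cells for agonist activity at Free fatty acid receptor 1 (Homo sapiens), read by FLIPR and calcium flux, in the presence of a further agent that is not named here (a higher number here means that more compound is needed for the effect, a lower number that less compound is needed), where compound 1 gives 13100 nM. Among the compounds with values here, that is the higher of the two numbers known so far. Compound 2, `O=C(O)CCc1ccc(OCc2nc(-c3ccccc3)no2)cc1`, gives 1130 nM in this assay, and the step of a 12-fold lower number from compound 1 to compound 2 (1.06 log units; beyond the scatter) came with hydrogen in place of chloro on an aromatic carbon. Compound 3, `Cc1cccc(-c2noc(COc3ccc(CCC(=O)O)cc3Cl)n2)c1`, is not yet measured. It differs from compound 1 by methyl in place of hydrogen on an aromatic carbon, on the phenyl that becomes 3-methylphenyl. Within the data shown here, no measured step bears on this change: the only known step concerns the chloro group, which compound 3 keeps. Nothing in the numbers points in either direction for a methyl, so a step within the scatter is expected in this assay, a 1.3-fold lower number from compound 1 to compound 3 (0.12 log units; within the scatter). Compound 3 is therefore estimated at 10000 nM, with a range from 3500 nM to 30000 nM.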

Compound 3, half-maximal effective concentration: 4580 nM
Estimate against measurement, compound 3: 2.2-fold (0.34 log units) above, within the range that was stated.
By their numbers in this assay, from the lowest: compound 2; then compound 3; then compound 1.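

The phenyl that becomes 3-methylphenyl proves to be a place that responds in this assay, as one added methyl gives a 2.9-fold lower number from compound 1 to compound 3 (0.46 log units; beyond the scatter). Within the data shown here, until now only the chloro group had been exchanged, so this is the first step read on the phenyl itself, and it is smaller in size than a 12-fold lower number from compound 1 to compound 2 (1.06 log units; beyond the scatter). No independent evidence on this series accounts for the methyl step.

From the compounds shown here alone, whether the same methyl would lower the number on the core of compound 2, which lacks the chloro group, stays open, since this step has been read only with the chloro group in place. Also open, going by these compounds, is how an ethyl or a methoxy group would compare with the methyl on this phenyl.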